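Permeability of a biaryl quinoline: estimating compound 4

The source may hold more compounds than are shown below. What is called first, only, known or untested is meant among the compounds shown, and "the series" means these compounds.

Measured so far:
- Compound 1, `COc1cccc(CNCCCNc2ccnc3cc(Cc4ccc(F)cc4)ccc23)c1O`: 23 10^-6 cm/s
- Compound 2, `COc1ccc(Oc2ccc3c(NCCCNCc4cccc(OC)c4O)ccnc3c2)cc1`: 317 10^-6 cm/s
- Compound 3, `COc1cccc(CNCCCNc2ccnc3cc(CC(C)C)ccc23)c1O`: 23 10^-6 cm/s

In an ADME assay for permeability, using PAMPA, with a stated time of 30 min, at pH 7.4 (a lower number here means that the compound crosses the layer more slowly, a higher number that the compound crosses the layer faster), compound 3 gives 23 10^-6 cm/s, level with compound 1 and together with it the lowest of the three numbers; compound 2 stands apart, as shown by a 14-fold lower number from compound 2 to compound 3 (1.14 log units; beyond the scatter).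

Compound 4, `COc1cccc(CNCCCNc2ccnc3cc(-c4ccc(C(F)(F)F)cc4)ccc23)c1O`, is not yet measured. It differs from compound 3 in one place: 4-(trifluoromethyl)phenyl in place of isobutyl on an aromatic carbon.

For the measured compounds named here, two measured steps touch the same position. Going from compound 1 to compound 3 exchanges one substituent on that carbon for another and gives no change at the digits printed from compound 1 to compound 3 (within the scatter). Going from compound 2 to compound 3 exchanges a different group there and gives a 14-fold lower number from compound 2 to compound 3 (1.14 log units; beyond the scatter). So the number at this position ranges widely among the compounds seen, with compound 2 far apart from compound 1 and compound 3, and no measured compound carries a ring bound directly to this aromatic carbon.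

Compound 4 is therefore expected to lie between the two extremes, with an estimated 2.0-fold higher number from compound 3 to compound 4 (0.29 log units; within the scatter) in this assay. The estimate for compound 4 is 45 10^-6 cm/s, with a range from 12 10^-6 cm/s to 180 10^-6 cm/s.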

Compound 4, apparent permeability: 237 10^-6 cm/s
The estimate for compound 4 lay 5.3-fold (0.72 log units) below the measured number; the measured number lies above the stated range.
By their numbers in this assay, from the lowest: compounds 1 and 3 (each within the scatter of the next); then compounds 4 and 2 (each within the scatter of the next).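

In this assay a ring bound directly to this aromatic carbon, as in the 4-(trifluoromethyl)phenyl group, gives a 10-fold higher number from compound 3 to compound 4 (1.01 log units; beyond the scatter) and also a 10-fold higher number from compound 1 to compound 4 (1.01 log units; beyond the scatter) at the same position. The 4-methoxyphenoxy group is therefore no longer alone in standing apart from the isobutyl and 4-fluorobenzyl groups here: the exchange for 4-(trifluoromethyl)phenyl gives a 1.3-fold lower number from compound 2 to compound 4 (0.13 log units; within the scatter) and so leaves the two level. Nothing measured on these compounds explains why the four groups divide in this way.

The compounds shown leave open how a plain phenyl ring would behave on this carbon, which would separate the effect of the directly bound ring from that of its trifluoromethyl group. They also leave open whether a ring carrying an amine or a carboxylic acid would fall with compound 2 and compound 4 or with compound 1 and compound 3.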